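This account rests on a few compounds, and the source may have more. Where it says the series, first, only, none or still open, it means among the compounds named here.

Measured in a functional assay on QGY cells (Homo sapiens) for cytotoxicity, read by MTT assay, with a stated time of 48 h; a lower number here means a stronger inhibitor, a higher number a weaker inhibitor:

- compound 1 `COc1cc([C@@H]2C[C@@]2(CO)C(=O)Nc2ccccc2)cc(OC)c1OC`: 36700 nM
- compound 2 `COc1cc([C@@H]2C[C@]2(CO)C(=O)Nc2ccccc2Cl)cc(OC)c1OC`: 15700 nM
- compound 3 `CCOC(=O)[C@]1(C(=O)Nc2ccccc2)C[C@H]1c1cc(OC)c(OC)c(OC)c1`: > 100000 nM

Compound 3 has no exact number on this scale, since its entry of > 100000 nM is only a limit of this assay. It carries ethoxycarbonyl, whereas compound 1 and compound 2 both carry hydroxymethyl and gave real numbers.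

Compound 4 `COc1cc([C@@H]2C[C@]2(CO)C(=O)Nc2ccccc2)cc(OC)c1OC` has not yet been measured. It differs from compound 3 by having hydroxymethyl in place of ethoxycarbonyl on a saturated ring carbon.

Compound 1 reads 36700 nM and compound 2 reads 15700 nM, so a move towards a lower number, and so stronger inhibition, is expected from this change, and it should exceed the usual scatter. On these data alone, the estimated change is an at least 3.3-fold lower number from compound 3 to compound 4 (0.52 log units; beyond the scatter), although its true size stays open, as the starting point is only a limit. For compound 4 the expected value is 30000 nM, with an estimated range from 10000 nM to 90000 nM.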

Compound 4, half-maximal inhibitory concentration: 51300 nM
Compound 4: middle estimate off by 1.7-fold (0.23 log units), on the low side, within the range that was stated.
By their numbers in this assay, from the lowest: compound 2; then compounds 1 and 4 (each within the scatter of the next). At a limit, above all of these: compound 3.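

In this assay, hydroxymethyl in place of ethoxycarbonyl on a saturated ring carbon gives an at least 1.9-fold lower number from compound 3 to compound 4 (0.28 log units; that floor lies within the scatter), so this pair alone does not firmly establish a gain, and the true size of the step stays unknown for one reason: the limit of > 100000 nM in this assay, at which 1 of the 4 values shown sits. Hydrogen in place of chloro on an aromatic carbon gives a 3.3-fold higher number from compound 2 to compound 4 (0.51 log units; beyond the scatter), which shows that the chloro-bearing compound 2 reads clearly lower than its direct partner. Changing only the drawn stereocentre gives a 1.4-fold higher number from compound 1 to compound 4 (0.15 log units; within the scatter), so that change makes no clear difference in this assay, and the comparison is clean for one reason: the fact that compounds 1 and 4 differ only in the configuration as drawn.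

On these data alone, how an aminomethyl or a carboxylic acid would read on the same saturated ring carbon remains open. So does whether fluoro or methyl in place of chloro would give a similar step.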